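Aryl sulfonyl variation on a shared quinoline-free core

This account rests on a few compounds, and the source may have more. Where it says the series, first, only, none or still open, it means among the compounds named here.

Compound 1 `Cc1cc(C)cc(S(=O)(=O)c2cnc3cc(F)ccc3c2N2CCC(C)CC2)c1`, compound 2 `COc1ccc(S(=O)(=O)c2cnc3cc(F)ccc3c2N2CCC(C)CC2)cc1` and compound 3 `CC1CCN(c2c(S(=O)(=O)c3ccc(C#N)cc3)cnc3cc(F)ccc23)CC1` share one core and differ only in the aryl group on the sulfonyl sulfur. In an assay on isolated protein for displacement of a labelled ligand from metabotropic glutamate receptor 5 (Homo sapiens), with a stated time of 60 min, tested at 1 uM (a higher number here means more inhibition at the concentration tested (going by the name of the read-out), a lower number less inhibition), compound 1 gives 80%, compound 2 gives 90% and compound 3 gives 83%. Of the three numbers compound 3 stands second highest; the nearest is a number 3 percentage points higher from compound 1 to compound 3 (within the scatter) and the furthest is a number 7 percentage points lower from compound 2 to compound 3 (within the scatter). Exchanging the whole aryl group, a number 10 percentage points higher from compound 1 to compound 2 (within the scatter), also stays within the scatter, so the three measured aryl groups are not separated by this assay.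

Compound 4 `Cc1ccc(S(=O)(=O)c2cnc3cc(F)ccc3c2N2CCC(C)CC2)cc1` has not yet been measured in this assay. It differs from compound 3 in one place: methyl in place of cyano on an aromatic carbon. Within the data shown here, two measured steps bear on this change, the step with 4-cyanophenyl in place of 3,5-dimethylphenyl and the step with cyano in place of methoxy; both fall within the scatter, so no step beyond the scatter is expected from compound 3 to compound 4 in this assay. For compound 4 the estimated value in this assay is 84%, with a range from 72% to 94%. The expected step is a number 1 percentage points higher from compound 3 to compound 4 (within the scatter).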

Compound 4, a percentage reported as inhibition, at one concentration (the size of the read-out at that concentration, not a potency): 88%
Estimate against measurement, compound 4: 4 percentage points below, within the range that was stated.
By their numbers in this assay, from the lowest: compounds 1, 3, 4 and 2 (each within the scatter of the next).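

Methyl in place of cyano at this position, on the aromatic carbon para to a large group, gives a number 5 percentage points higher from compound 3 to compound 4 (within the scatter) in this assay and thus removes the triple bond and the hydrogen-bond acceptor of the nitrile without a step beyond the scatter. Methyl in place of methoxy at the same position gives a number 2 percentage points lower from compound 2 to compound 4 (within the scatter) and 4-methylphenyl in place of 3,5-dimethylphenyl gives a number 8 percentage points higher from compound 1 to compound 4 (within the scatter) so the series now has three groups at this position and one with a different placement of methyl, and none of the four aryl groups is separated from the others. No measurement is at hand that could account for these numbers.

On these data alone, whether an amine, a carboxylic acid or a longer chain such as butyl at this position would move the number beyond the scatter remains open, as does the effect of any change to the shared core outside the sulfonyl aryl group. The read-out is also taken at one concentration, so it leaves open whether the four compounds differ in potency.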